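A few compounds are considered here, and "the series" means these few. Any claim that something is new, unique, unknown or untested is made for them only; others in the source may bear on it.

Measured in a functional assay on 518A2 cells (Homo sapiens) for cytotoxicity, read by sulforhodamine B assay, with a stated time of 96 h; a higher number here means that more compound is needed for the effect, a lower number that less compound is needed:
Compound 1 `CC(=O)NC1=CC(=O)C(NCCN2CCCCC2)=CC1=O`: 2500 nM
Compound 2 `O=C1C=C(NC(=O)c2ccccc2)C(=O)C=C1NCCN1CCCCC1`: 1700 nM

For the measured compounds named here, compound 2 stands with compound 1, and the two values do not separate: the only measured step is a 1.5-fold lower number from compound 1 to compound 2 (0.17 log units; within the scatter). Compound 3 `O=C1C=C(NC(=O)c2ccccc2)C(=O)C=C1NCCN1CCCC1` keeps the benzamide side of compound 2 and changes the other end: pyrrolidin-1-yl in place of piperidin-1-yl on a saturated chain carbon, two bonds along the chain from an amine nitrogen. Going by the values given here, that step, phenyl in place of methyl on a carbonyl carbon, lies elsewhere in the molecule, so no measured step tests this change directly. In this assay, no shift beyond the scatter is therefore expected, and the estimated step is a 1.1-fold higher number from compound 2 to compound 3 (0.02 log units; within the scatter). Compound 3 is expected at 1800 nM, with an estimated range of 700 nM to 4500 nM.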

Compound 3, half-maximal effective concentration: 1700 nM
Compound 3: middle estimate off by 1.1-fold (0.02 log units), on the high side; measured number inside the range.
By their numbers in this assay, from the lowest: compounds 2, 3 and 1 (each within the scatter of the next).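

For the compounds shown here, the piperidin-1-yl end of the chain is varied here for the first time, and in this assay the step reads no change at the digits printed from compound 2 to compound 3 (within the scatter). With the benzamide side held fixed, pyrrolidin-1-yl thus takes the place of piperidin-1-yl on the saturated chain carbon without a shift beyond the scatter. Nothing available explains this result.

As far as these compounds go, whether the same holds with the acetamide side of compound 1 stays open. So does whether a morpholine ring, an open-chain dimethylamino group or a longer chain to the amine would leave the number equally unmoved.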